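Bromo to nitro on the weak end of the series

This account rests on a few compounds, and the source may have more. Where it says the series, first, only, none or still open, it means among the compounds named here.

Measured so far:
- compound 1 `CCN(Cc1cnc2nc(N)nc(N)c2n1)c1c(Cl)cc(C(=O)N[C@@H](CCC(=O)O)C(=O)O)cc1Cl`: 0.022 ug/mL
- compound 2 `CN(Cc1cnc2nc(N)c(Br)c(N)c2n1)c1ccc(C(=O)N[C@@H](CCC(=O)O)C(=O)O)cc1`: 76 ug/mL

In a functional assay on KB cells (Homo sapiens) for cytotoxicity (on this read-out lower numbers stand for an effect already at smaller amounts and higher numbers for an effect only at larger amounts of compound), compound 2, at 76 ug/mL, holds the higher of the two numbers, and compound 1 lies lower by a gap well beyond the scatter. Compound 3 `CN(Cc1cnc2nc(N)c([N+](=O)[O-])c(N)c2n1)c1ccc(C(=O)N[C@@H](CCC(=O)O)C(=O)O)cc1` has nitro in place of bromo on an aromatic carbon. Among the measured compounds shown here, no measured pair covers this change, so the expectation remains loose. In this assay the expected step is a 1.5-fold lower number from compound 2 to compound 3 (0.18 log units; within the scatter), which is none beyond the scatter. For compound 3 the estimate is 50 ug/mL, with an expected range of 10 ug/mL to 200 ug/mL.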

Compound 3, concentration for half-maximal effect in the KB assay: > 100 ug/mL
Compound 3 gave a limit, no number; the forecaster's own chance of this, stated with the estimate: 20%; at least 2.0-fold (0.30 log units) between middle value and limit.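

On an aromatic carbon ortho to two amino groups, nitro in place of bromo gives in the KB assay an at least 1.3-fold higher number from compound 2 to compound 3 (0.11 log units; that floor lies within the scatter), so this single change does not recover the effect missing from compound 2. The result for compound 3 is a limit, not a number: the limit of > 100 ug/mL in the KB assay, at which 1 of the 3 values shown sits. In a physicochemical assay for acid dissociation, compound 2 gives 5.1 and compound 3 gives 4.3, so the same change does shift acid dissociation: the measured acid dissociation constant of compound 2, 5.1, and of compound 3, 4.3, a number 0.80 log units lower (beyond the scatter).

One pair cannot tie that shift to the read-out in the KB assay. Also open, from the compounds shown here alone, is how an amine or a nitrile on this aromatic carbon would behave in either assay.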